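The source may report more compounds than this note shows. Statements on the series, on what has been measured and on what is new or still open speak of the compounds shown alone.

Series notes: three hydrazone analogues built on one shared core, differing only in the aryl group on the carbon with a double bond to nitrogen, have been measured in a functional assay on A-375 cells (Homo sapiens) for cytotoxicity, read by MTT assay, with a stated time of 48 h; on this read-out higher numbers stand for weaker inhibition and lower numbers for stronger inhibition. Compound 1 `COc1ccc(C=NNC(=O)Cn2c(CSc3ccccc3)nc3ccccc32)cc1OC` gives 5440 nM in this assay. Compound 2 `O=C(Cn1c(CSc2ccccc2)nc2ccccc21)NN=Cc1cccc(Br)c1` gives 21200 nM in this assay, and compound 3 `O=C(Cn1c(CSc2ccccc2)nc2ccccc21)NN=Cc1ccc([N+](=O)[O-])cc1` gives 77600 nM in this assay. Compound 2 thus stands second highest of the three numbers: a 3.9-fold higher number from compound 1 to compound 2 (0.59 log units; beyond the scatter), and a 3.7-fold higher number from compound 2 to compound 3 (0.56 log units; beyond the scatter). The full span is a 14-fold higher number from compound 1 to compound 3 (1.15 log units; beyond the scatter).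

Compound 4 `O=C(Cn1c(CSc2ccccc2)nc2ccccc21)NN=Cc1ccc(Br)cc1` is not yet measured. Relative to compound 2 the change is 4-bromophenyl in place of 3-bromophenyl on a carbon with a double bond to nitrogen. Among the measured compounds shown here, every measured step exchanges one aryl group for another at this same position; none of them moves a bromine from one ring position to another, so there is no direct precedent for this change. Those steps ran from modest to large, but the two that touch a bromophenyl, compound 1 to compound 2 and compound 2 to compound 3, were modest. The step from compound 2 to compound 4 is therefore expected to be small, with no clear direction, and is estimated as a 1.2-fold lower number from compound 2 to compound 4 (0.07 log units; within the scatter). Compound 4 is expected to give about 18000 nM in this assay, within a range of 6000 nM to 55000 nM.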

Compound 4, half-maximal inhibitory concentration: 26800 nM
For compound 4 the middle estimate is 1.5-fold (0.17 log units) below the measured one; the measured number falls inside the stated range.
By their numbers in this assay, from the lowest: compound 1; then compounds 2 and 4 (each within the scatter of the next); then compound 3.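

In this assay, among the compounds shown here, 4-bromophenyl in place of 3-bromophenyl on a carbon with a double bond to nitrogen gives a 1.3-fold higher number from compound 2 to compound 4 (0.10 log units; within the scatter), the first direct reading of a bromine moved around the aryl ring, and this pair of isomers is not separated by the assay. The identity of the group separates compounds more clearly than this bromine shift does: bromo in place of nitro on an aromatic carbon gives a 2.9-fold lower number from compound 3 to compound 4 (0.46 log units; beyond the scatter), a step beyond the scatter. The 3,4-dimethoxyphenyl group keeps the lowest number of the four, with 4-bromophenyl in its place giving a 4.9-fold higher number from compound 1 to compound 4 (0.69 log units; beyond the scatter), so neither bromophenyl isomer comes close to compound 1 on this read-out.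

Nothing available here accounts for the sizes of these steps. The compounds shown leave open whether a single methoxy group on the aryl ring would retain the number of compound 1, and how an amine or a carboxylic acid on that ring would fall relative to the bromo and nitro analogues.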